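Dihydrofuran carboxamides: cytotoxicity on HeLa cells

The source may hold more compounds than are shown below. What is called first, only, known or untested is meant among the compounds shown, and "the series" means these compounds.

Measured compounds:
compound 1 `C=CC1=C(C(=O)NCc2ccc(C)cc2)C(c2ccc(F)cc2)OC1`; in a functional assay on HeLa cells (Homo sapiens) for cytotoxicity, read by MTT assay, with a stated time of 24 h (on this read-out higher numbers stand for weaker inhibition and lower numbers for stronger inhibition), compound 1 gives > 100000 nM, a limit of the assay.
compound 2 `C=CC1=C(C(=O)NCc2ccccc2F)C(c2ccc(F)cc2)OC1`; compound 2 gives > 100000 nM, again a limit.
compound 3 `C=CC1=C(C(=O)NCc2ccc(C)cc2)C(c2ccc(OC)cc2)OC1`; compound 3 gives 15900 nM.

Compound 1 and compound 2 differ by 2-fluorophenyl in place of 4-methylphenyl on a saturated chain carbon bound to an amide-type nitrogen. The step that the two limits leave unreadable from compound 1 to compound 2, since both values sit at the limit of > 100000 nM in this assay, at which 2 of the 3 values shown sit. Compound 1 and compound 3 differ in the core by methoxy in place of fluoro on an aromatic carbon, and here the step is readable: an at least 6.2-fold lower number from compound 1 to compound 3 (0.79 log units; beyond the scatter). Within the data shown here, compound 3 is thus the only compound of the three with a number rather than a limit.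

Compound 4 `C=CC1=C(C(=O)NCc2ccccc2F)C(c2ccc(OC)cc2)OC1` has not been measured. It differs from compound 3 by 2-fluorophenyl in place of 4-methylphenyl on a saturated chain carbon bound to an amide-type nitrogen, the same change as between compound 1 and compound 2, made on the same place. That earlier step gives no size, so the expectation for compound 4 rests on the value of compound 3, 15900 nM, with a step of a 1.9-fold higher number from compound 3 to compound 4 (0.28 log units; within the scatter) expected as a broad guess. Compound 4 is estimated at 30000 nM, within 8000 nM to 120000 nM.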

Compound 4, half-maximal inhibitory concentration: > 100000 nM
Compound 4: only a limit was reported; the forecaster's own chance of this, stated with the estimate: 35%; middle value at least 3.3-fold (0.52 log units) from the limit.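

In this assay, the change from 4-methylbenzyl to 2-fluorobenzyl on the core of compound 3 gives an at least 6.2-fold higher number from compound 3 to compound 4 (0.79 log units; beyond the scatter), so on this core the 2-fluorobenzyl amide loses the measurable cytotoxicity seen with 4-methylbenzyl. The same change on the core of compound 1, and the methoxy in place of fluoro step from compound 2 to compound 4, cannot be read, since both ends of each pair sit at one limit: the limit of > 100000 nM in this assay, at which 3 of the 4 values shown sit. Carrying the change from one core to another is therefore neither confirmed nor refuted, as the size seen on the core of compound 3 has no readable counterpart on the core of compound 1.

Compound 3 gives 15900 nM. Open, from the compounds shown here alone, is whether any other amide substituent on this core can give a lower number. Also open, going by these compounds, is how an amine or a carboxylic acid on the benzyl ring, or a longer chain in place of the benzyl group, would read in this assay.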